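Swapping a Fused Bicyclic Aryl for a Single Chlorophenyl

The source may hold more compounds than are shown below. What is called first, only, known or untested is meant among the compounds shown, and "the series" means these compounds.

Three compounds have been measured in a functional assay on A549 cells (Homo sapiens) for antiproliferative activity, with a stated time of 5 days; a higher number here means a weaker inhibitor, a lower number a stronger inhibitor:
compound 1 `O=C1C=CC2(C=C1)OCC(=O)N2c1nc(-c2ccc3ccccc3c2Br)nn1-c1ccccc1` gives 100 nM;
compound 2 `O=C1C=CC2(C=C1)OCC(=O)N2c1nc(-c2ccc3c(c2)OCCO3)nn1-c1ccccc1` gives 170 nM;
compound 3 `O=C1C=CC2(C=C1)OCC(=O)N2c1nc(-c2ccc3ccccc3c2)nn1-c1ccccc1` gives 140 nM.

Compound 3 holds the second highest of these three numbers, and it sits within the scatter of both neighbours (a 1.2-fold lower number from compound 2 to compound 3 (0.08 log units; within the scatter); a 1.4-fold higher number from compound 1 to compound 3 (0.15 log units; within the scatter)). Compound 4 `O=C1C=CC2(C=C1)OCC(=O)N2c1nc(-c2cccc(Cl)c2)nn1-c1ccccc1` carries 3-chlorophenyl in place of naphthalen-2-yl on an aromatic carbon. Among the compounds with values here, no measured step trades a group of two fused aromatic rings for a single substituted ring; the nearest comparison, a 1.7-fold higher number from compound 1 to compound 2 (0.23 log units; within the scatter), exchanges one two-ring group for another and stays within the scatter, as does a 1.4-fold higher number from compound 1 to compound 3 (0.15 log units; within the scatter), where only bromo is removed. On this evidence no step beyond the scatter is expected, though the lack of any single-ring comparator widens the range. Compound 4 is estimated at 200 nM, between 80 nM and 600 nM, a step of a 1.4-fold higher number from compound 3 to compound 4 (0.15 log units; within the scatter).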

Compound 4, half-maximal inhibitory concentration: 25.2 nM
For compound 4 the middle estimate is 7.9-fold (0.90 log units) above the measured one; the measured number lies below the stated range.
By their numbers in this assay, from the lowest: compound 4; then compounds 1, 3 and 2 (each within the scatter of the next).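

In this assay, the two-ring groups on this aromatic carbon had stayed within the scatter of one another, but the single ring of 3-chlorophenyl moves the number beyond it against each of them (a 5.6-fold lower number from compound 3 to compound 4 (0.74 log units; beyond the scatter)) (a 6.7-fold lower number from compound 2 to compound 4 (0.83 log units; beyond the scatter)) (a 4.0-fold lower number from compound 1 to compound 4 (0.60 log units; beyond the scatter)). Compound 4 therefore stands apart from all three two-ring compounds, so this position does respond to the aryl group it carries. Nothing available accounts for this difference. From the compounds shown here alone, whether the step belongs to the chlorine or to the single ring remains open. So does how an unsubstituted phenyl or a 3-methoxyphenyl would read here.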